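A few compounds are considered here, and "the series" means these few. Any claim that something is new, unique, unknown or untested is made for them only; others in the source may bear on it.

Measured compounds:
Compound 1, `O=C(CSC(=S)N[C@H]1CCOC1=O)Nc1ccc(Br)cc1`, in a functional assay on SMMC-7721 cells (Homo sapiens) for cytotoxicity, read by MTT assay, with a stated time of 72 h (on this read-out lower numbers stand for stronger inhibition and higher numbers for weaker inhibition), gives 28300 nM.
Compound 2, `O=C(CSC(=S)N[C@H]1CCOC1=O)Nc1cccc(Cl)c1`, in this assay reaches only the limit > 128000 nM.

For the measured compounds named here, compound 2 thus stands at the limit of this assay with no number of its own; its one known step is an at least 4.5-fold higher number from compound 1 to compound 2 (0.65 log units; beyond the scatter), which rests on (the limit of > 128000 nM in this assay, at which 1 of the 2 values shown sits). Compound 3, `O=C(CSC(=S)N[C@H]1CCOC1=O)Nc1ccc(F)cc1`, is not yet measured in this assay. It differs from compound 2 by 4-fluorophenyl in place of 3-chlorophenyl on an amide-type nitrogen. Going by the values given here, the only measured step that bears on this change is an at least 4.5-fold higher number from compound 1 to compound 2 (0.65 log units; beyond the scatter): the 4-bromophenyl compound gave the stronger number and the 3-chlorophenyl compound the weaker. Compound 3 carries a 4-fluorophenyl, so its halogen pattern follows compound 1 rather than compound 2. A lower number than the limit of compound 2 is therefore expected for compound 3, with an expected step of an at least 2.5-fold lower number from compound 2 to compound 3 (0.40 log units; beyond the scatter). Compound 3 is estimated at 50000 nM, between 15000 nM and 160000 nM.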

Compound 3, half-maximal inhibitory concentration: > 128000 nM
Compound 3: no number, only a limit (the forecaster's own chance of this, stated with the estimate: 35%); middle value at least 2.5-fold (0.40 log units) from the limit.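

In this assay, the 4-fluorophenyl on the amide-type nitrogen does not keep the measurable inhibition of the 4-bromophenyl: the change of fluoro in place of bromo on an aromatic carbon gives an at least 4.5-fold higher number from compound 1 to compound 3 (0.65 log units; beyond the scatter). The number of compound 1 therefore does not extend to every halogen carried at the 4 position of the phenyl, and the earlier contrast with the 3-chlorophenyl of compound 2 cannot be read as an effect of halogen position alone. Compound 3 reaches only the limit > 128000 nM, and since compound 2 is also a limit, the step between them cannot be read, leaving compound 1 as the only one with a number of its own: the limit of > 128000 nM in this assay, at which 2 of the 3 values shown sit.

On these data alone, how far compound 2 and compound 3 lie beyond that limit stays open. So does whether a 4-chlorophenyl or 4-iodophenyl on the same nitrogen would give a number like that of compound 1.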